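The source may hold more compounds than are shown below. What is called first, only, known or untested is meant among the compounds shown, and "the series" means these compounds.

In an ADME assay on HOS cells (Homo sapiens) for cytotoxicity (on this read-out higher numbers stand for lower toxicity in this test and lower numbers for higher toxicity in this test), compound 1 (`CN1CCC[C@H](Cn2c(CN(C)[C@H]3CCCc4cccnc43)nc3ccccc32)C1`) gives 3600 nM and compound 2 (`CN1CCC[C@@H](Cn2c(CN(C)[C@H]3CCCc4cccnc43)nc3ccccc32)C1`) gives 3500 nM. Compound 3 (`CC(C)CN1CCC[C@H](Cn2c(CN(C)[C@H]3CCCc4cccnc43)nc3ccccc32)C1`) is recorded only as a limit, > 2000 nM. Compound 4 (`CC(C)CCN1CCC[C@H](Cn2c(CN(C)[C@H]3CCCc4cccnc43)nc3ccccc32)C1`) differs from it by one change, isobutyl in place of isopropyl on a saturated chain carbon bound to an amine nitrogen in a ring. Within the data shown here, the only readable measured step, a 1.0-fold lower number from compound 1 to compound 2 (0.01 log units; within the scatter), lies within the scatter and rests on (the fact that compounds 1 and 2 differ only in the configuration as drawn), not on this substituent. The steps that do alter this substituent, a step that the limit leaves unreadable from compound 1 to compound 3 and a step that the limit leaves unreadable from compound 2 to compound 3, have no readable size because of the limit of > 2000 nM in this assay, at which 1 of the 3 values shown sits. No step beyond the scatter is therefore expected in this assay, and no direction can be named. The expected step is a step that the limit leaves unreadable from compound 3 to compound 4. Compound 4 is estimated at 2800 nM, with an expected range from 1200 nM to 6000 nM.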

Compound 4, half-maximal cytotoxic concentration: 2300 nM
For compound 4 the middle estimate is 1.2-fold (0.09 log units) above the measured one; measured number inside the range.
By their numbers in this assay, from the lowest: compounds 4, 2 and 1 (each within the scatter of the next).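

In this assay, among these compounds, lengthening the substituent on a saturated chain carbon bound to an amine nitrogen in a ring now has a readable size for the first time: a 1.6-fold lower number from compound 1 to compound 4 (0.19 log units; within the scatter) and a 1.5-fold lower number from compound 2 to compound 4 (0.18 log units; within the scatter). The isobutyl group thus leaves the number within the scatter of the compounds that lack it. The steps to and from compound 3 cannot be read, because of this: the limit of > 2000 nM in this assay, at which 1 of the 4 values shown sits.

From the compounds shown here alone, whether a carboxylic acid or a longer chain in place of isobutyl would move the number in this assay beyond the scatter stays open.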